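This account rests on a few compounds, and the source may have more. Where it says the series, first, only, none or still open, it means among the compounds named here.

The measured compounds:

Compound 1, `COc1cc(/C=C/C(=O)c2cccc(-n3cc(-c4ccc(Cl)cc4)[nH]c3=O)c2)cc(OC)c1OC`, gives 1720 nM.
Compound 2, `O=C(/C=C/c1cccc(O)c1)c1cccc(-n2cc(-c3ccccc3)[nH]c2=O)c1`, gives 1850 nM.
Compound 3, `O=C(/C=C/c1cccc(O)c1)c1cccc(-n2cc(-c3ccc(Cl)cc3)[nH]c2=O)c1`, gives 1570 nM.

All three numbers come from a functional assay on LOX IMVI cells (Homo sapiens) for inhibition; a higher number here means a weaker inhibitor of growth, a lower number a stronger inhibitor of growth. They lie close together: compound 1 and compound 2 fall within the scatter of each other, and so do compound 1 and compound 3, so none of the three can be called the stronger or the weaker inhibitor on this evidence.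

Compound 4, `COc1cc(/C=C/C(=O)c2cccc(-n3cc(-c4ccccc4)[nH]c3=O)c2)cc(OC)c1OC`, has not yet been measured in this assay. It is related to compound 1 by a single change: hydrogen in place of chloro on an aromatic carbon. The same change has already been made once among the measured compounds, from compound 3 to compound 2: hydrogen in place of chloro on an aromatic carbon. There it made a step of a 1.2-fold higher number from compound 3 to compound 2 (0.07 log units; within the scatter), so the number hardly moved. The place of the change is described in exactly the same way in both pairs, so it is the same change, carried out on two different cores. Compound 1 and compound 3 differ in their cores, but the difference between the two cores is not broken down here.

Because the earlier step was a 1.2-fold higher number from compound 3 to compound 2 (0.07 log units; within the scatter), the step expected now is a 1.2-fold higher number from compound 1 to compound 4 (0.07 log units; within the scatter). For compound 4 this gives an estimated value of 2000 nM. The estimate for compound 4 is expected to fall between 1000 nM and 4000 nM.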

Compound 4, concentration for 50% growth inhibition: 480 nM
Estimate against measurement, compound 4: 4.2-fold (0.62 log units) above; measured number below the stated range.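

In this assay, replacing 4-chlorophenyl with phenyl on the core of compound 1 gives a 3.6-fold lower number from compound 1 to compound 4 (0.55 log units; beyond the scatter), so here the compound without the chloro is the stronger inhibitor of growth. Going by these compounds alone, the same swap on the other core barely moved the number, so the change did not carry over from one core to the other with the same size of effect: the same change on two cores in this assay, a 1.2-fold higher number (0.07 log units; within the scatter) from compound 3 to compound 2 and a 3.6-fold lower number (0.55 log units; beyond the scatter) from compound 1 to compound 4, 4.2-fold (0.63 log units) apart, beyond the scatter of two such steps What this does not show is which feature of the two cores separates them, or why the step is larger on one than on the other, and with only two pairs it gives no rule for what the swap would do on any further core.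

The compounds shown leave open whether a fluoro or a methyl group in the place of the chloro, on the core of compound 1, would give a number closer to that of compound 1 or that of compound 4. They also leave open which of the differences between the two cores matters, something that a series changing one part of the core at a time, with and without the chloro, could begin to settle.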